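The source may hold more compounds than are shown below. What is called first, only, known or untested is meant among the compounds shown, and "the series" means these compounds.

Values in a functional assay on HL-60 cells (Homo sapiens) for inhibition, read by resazurin assay, with a stated time of 72 h; a higher number here means a weaker inhibitor, a lower number a stronger inhibitor:
- compound 1 `CCSc1ccc(C2C(Oc3ccccc3)C(=O)N2c2cc(OC)c(OC)c(OC)c2)cc1`: 508 nM
- compound 2 `C=CC1C(=O)N(c2cc(OC)c(OC)c(OC)c2)C1c1ccc(SC)cc1`: 61 nM
- compound 3 `C=CC1C(=O)N(c2cc(OC)c(OC)c(OC)c2)C1c1ccc(SCC)cc1`: 320 nM

Two steps fix the standing of compound 3 among these numbers: a 1.6-fold lower number from compound 1 to compound 3 (0.20 log units; within the scatter), and a 5.2-fold higher number from compound 2 to compound 3 (0.72 log units; beyond the scatter). Only compound 2 is clearly separated from it.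

The next compound is compound 4 `C=CC1C(=O)N(c2cc(OC)c(OC)c(OC)c2)C1c1ccc(OC)cc1`, with methoxy in place of ethylsulfanyl on an aromatic carbon, para to a large group: methoxy in place of ethylsulfanyl on an aromatic carbon.

The step from compound 1 changes a different place and says little here. The step from compound 2 bears directly, since it changes the same substituent and its size is the best available guide. Among the compounds with values here, no measured pair exchanges sulfur for oxygen, so the transfer is uncertain. Compound 4 keeps the shorter chain of compound 2, which gives 61 nM, so a value near that one is expected in this assay.

The expected change is a 4.6-fold lower number from compound 3 to compound 4 (0.66 log units; beyond the scatter), of similar size to the step from compound 2 but in the opposite direction.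

For compound 4 the estimate is 70 nM, with an expected range of 20 nM to 250 nM.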

Compound 4, half-maximal inhibitory concentration: 33 nM
Compound 4: the middle estimate sits 2.1-fold (0.33 log units) above what was measured; low and high end bracket the measured number.
By their numbers in this assay, from the lowest: compounds 4 and 2 (each within the scatter of the next); then compounds 3 and 1 (each within the scatter of the next).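

In this assay, methoxy in place of ethylsulfanyl on the aromatic carbon para to a large group gives a 9.7-fold lower number from compound 3 to compound 4 (0.99 log units; beyond the scatter) and extends the comparison at this place from sulfur-linked chains to an oxygen-linked group. Methoxy in place of methylsulfanyl gives a 1.8-fold lower number from compound 2 to compound 4 (0.27 log units; within the scatter) and so does not separate these two short groups, which leaves ethylsulfanyl in compound 3 clearly apart from both compound 2 and compound 4 among the vinyl compounds. No measurement is available that bears on the cause of these differences.

Ethoxy at this place would show whether the loss seen with ethylsulfanyl follows the chain length or depends on the sulfur. Also open, on these data alone, are a longer chain such as propoxy, an amine at this place, and how methoxy behaves with phenoxy in place of vinyl on the shared core.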